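The source may hold more compounds than are shown below. What is called first, only, known or untested is meant among the compounds shown, and "the series" means these compounds.

Compound 3 `CC(=O)c1ccc(S(=O)(=O)NC(C2=CC(=O)c3c(O)ccc(O)c3C2=O)C(C)C)cc1` gives 3820 nM in a functional assay on HeLa cells (Homo sapiens) for cytotoxicity, read by sulforhodamine B assay (a higher number here means a weaker inhibitor, a lower number a stronger inhibitor), the second highest of three numbers: compound 1 `CC(C)C(NS(=O)(=O)c1cccc(Br)c1)C1=CC(=O)c2c(O)ccc(O)c2C1=O` gives 860 nM and compound 2 `CC(C)C(NS(=O)(=O)c1ccccc1Br)C1=CC(=O)c2c(O)ccc(O)c2C1=O` gives 8310 nM, with a 4.4-fold higher number from compound 1 to compound 3 (0.65 log units; beyond the scatter) and a 2.2-fold lower number from compound 2 to compound 3 (0.34 log units; beyond the scatter). Compound 4 `CC(=O)c1ccc(S(=O)(=O)NC(C)C2=CC(=O)c3c(O)ccc(O)c3C2=O)cc1` differs from compound 3 by methyl in place of isopropyl on a saturated chain carbon bound to a double-bonded ring carbon and a sulfonamide nitrogen. For the measured compounds named here, all three measured steps, a 9.7-fold higher number from compound 1 to compound 2 (0.99 log units; beyond the scatter) among them, vary only the group on the sulfonyl sulfur; none touches the saturated chain carbon, so no measured step bears on this change. With nothing in the series to read a direction from, a step of a 1.2-fold higher number from compound 3 to compound 4 (0.07 log units; within the scatter) in this assay is expected, inside the scatter, with a wide uncertainty. Compound 4 is accordingly estimated at 4500 nM, in a range from 1500 nM to 14000 nM.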

Compound 4, half-maximal inhibitory concentration: 5760 nM
The estimate for compound 4 lay 1.3-fold (0.11 log units) below the measured number, within the range that was stated.
By their numbers in this assay, from the lowest: compound 1; then compounds 3, 4 and 2 (each within the scatter of the next, the first and the last beyond it).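

In this assay, for the compounds shown here, methyl in place of isopropyl on the saturated chain carbon gives a 1.5-fold higher number from compound 3 to compound 4 (0.18 log units; within the scatter), the first reading at this position, taken with 4-acetylphenyl on the sulfonyl sulfur. The assay does not separate these two groups here, whereas every step at the sulfonyl sulfur lies beyond the scatter. Nothing available explains this result.

From the compounds shown here alone, whether the same holds with 3-bromophenyl on the sulfonyl sulfur remains open. So does the outcome with a longer chain, a phenyl ring or an amine on the chain carbon.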